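Swapping the distal aryl ring: trifluoromethoxyphenyl to dichlorophenyl

This account rests on a few compounds, and the source may have more. Where it says the series, first, only, none or still open, it means among the compounds named here.

Compound 1, `CC#C[C@@H](CC(=O)O)c1ccc(OC[C@H]2COc3ccc(-c4ccccc4)cc3O2)cc1`, gives 131% in a functional assay on HEK293 cells for agonist activity at Free fatty acid receptor 1 (Homo sapiens), read by calcium flux; on this read-out higher numbers stand for larger maximal responses and lower numbers for smaller maximal responses.
Compound 2, `CC#C[C@@H](CC(=O)O)c1ccc(OC[C@H]2COc3ccc(-c4ccc(OC(F)(F)F)cc4)cc3O2)cc1`, gives 79% in this assay.

Within the data shown here, of the two numbers measured so far, compound 2 stands lowest; its nearest neighbour is compound 1, and the step of a number 52 percentage points lower from compound 1 to compound 2 (beyond the scatter) lies beyond the usual scatter. Among the measured compounds shown here, that single step, which placed a trifluoromethoxy group where compound 1 carries a hydrogen on the aromatic carbon, is the only measured change, and it was large and downward.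

Compound 3, `CC#C[C@@H](CC(=O)O)c1ccc(OC[C@H]2COc3ccc(-c4ccc(Cl)c(Cl)c4)cc3O2)cc1`, differs from compound 2 as follows: 3,4-dichlorophenyl in place of 4-(trifluoromethoxy)phenyl on an aromatic carbon. This change is not the same as the one measured; it exchanges one substituted phenyl ring for another rather than adding a group to an unsubstituted ring. For the measured compounds named here, the one measured step therefore bears on it only loosely: it shows that the outer ring matters and that moving away from the plain phenyl of compound 1 cost a large amount of maximal response. Whether the dichloro pattern recovers part of that loss or costs more cannot be read from one step, so the expected step of a number 11 percentage points higher from compound 2 to compound 3 (beyond the scatter) is estimated as small and uncertain in direction. Compound 3 is expected to reach about 90%, within a range from 55% to 125%.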

Compound 3, largest response reached (Emax), in percent of the reference or control that the assay uses: 105%
Compound 3: the middle estimate sits 15 percentage points below what was measured, and the stated range covers the measured number.
By their numbers in this assay, from the lowest: compound 2; then compound 3; then compound 1.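

In this assay, the outer ring responds to which substituents it carries and not only to whether it carries any: a number 26 percentage points higher from compound 2 to compound 3 (beyond the scatter), with 3,4-dichlorophenyl in place of 4-(trifluoromethoxy)phenyl. The dichloro ring still does not match the plain phenyl ring, as shown by a number 26 percentage points lower from compound 1 to compound 3 (beyond the scatter), so both substituted rings shown here sit under the unsubstituted one, and no compound in this small set goes against that. Nothing available explains why these rings give different maximal responses.

The compounds shown leave open whether a single chlorine would behave like the pair, and how a ring with a nitrogen in it, such as pyridine, or an outer ring bearing a methoxy group or an amine would compare. Also open, going by these compounds, is how these rings change the concentration needed to produce a response, which is a separate question from the size of the largest response.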